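Cyclopropyl to hydrogen on compound 1: working notes

This account rests on a few compounds, and the source may have more. Where it says the series, first, only, none or still open, it means among the compounds named here.

- compound 1 `COc1nc(NC2CC2)c2ncn([C@H]3C[C@H](N=[N+]=[N-])[C@@H](CO)O3)c2n1`: > 100000 nM (a limit)
- compound 2 `[N-]=[N+]=N[C@H]1C[C@H](n2cnc3c(NC4CC4)nc(Cl)nc32)O[C@@H]1CO`: > 100000 nM (a limit)
- compound 3 `[N-]=[N+]=N[C@H]1C[C@H](n2cnc3c(NC4CC4)nc(N)nc32)O[C@@H]1CO`: > 100000 nM (a limit)

The read-out is an ADME assay on CCRF-CEM cells (Homo sapiens) for cytotoxicity, with a stated time of 5 days; on this read-out lower numbers stand for stronger inhibition and higher numbers for weaker inhibition. In this assay compound 1 gives > 100000 nM, which is a limit and not a number. The series offers no numerical value for comparison: the limit of > 100000 nM in this assay, at which 3 of the 3 values shown sit.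

Compound 4 `COc1nc(N)c2ncn([C@H]3C[C@H](N=[N+]=[N-])[C@@H](CO)O3)c2n1` follows from compound 1 by one change, cyclopropylamino to amino: hydrogen in place of cyclopropyl on a nitrogen on an aromatic ring.

The measured steps bear on it only indirectly. All of them exchange groups on an aromatic carbon and keep the cyclopropyl: a step that the two limits leave unreadable from compound 1 to compound 2, a step that the two limits leave unreadable from compound 1 to compound 3, a step that the two limits leave unreadable from compound 2 to compound 3. None has a readable size, and none measures the loss of cyclopropyl. No step beyond the scatter can therefore be argued from these data, and no direction is favoured. A further result at the limit is the most likely outcome. The expected step is a number no higher from compound 1 to compound 4 (the limit leaves the size open). For compound 4 the estimated value is 100000 nM, with an expected range of 30000 nM to 200000 nM.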

Compound 4, half-maximal inhibitory concentration: > 100000 nM
Compound 4 was reported as a limit (the forecaster's own chance of this, stated with the estimate: 70%); the middle value sits exactly at the limit.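

Going by these compounds alone, compound 1 and compound 4 both stand only as limits, so no step from hydrogen in place of cyclopropyl can be read, and the whole series sits at one ceiling: the limit of > 100000 nM in this assay, at which 4 of the 4 values shown sit. The compounds shown leave open whether any of these changes alters cytotoxicity, and in which direction.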